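Iodo in place of methyl: notes toward compound 4

The source may hold more compounds than are shown below. What is called first, only, known or untested is meant among the compounds shown, and "the series" means these compounds.

Of the compounds shown here, three have been read in an assay for inhibition of protein mono-ADP-ribosyltransferase PARP4 (Homo sapiens), read by chemiluminescence, with stated times of 10 min and 60 min; on this read-out higher numbers stand for weaker inhibition and lower numbers for stronger inhibition. Compound 2 `Cc1cc(C)c2nc(CSc3ncccn3)[nH]c(=O)c2c1` gives 500 nM, the lowest of the three numbers. Compound 1 `Cc1cc(I)cc2c(=O)[nH]c(CSc3ccc(C(=O)O)cc3)nc12` gives 800 nM, which lies within the scatter of compound 2. Compound 3 `Cc1cc(Br)cc2c(=O)[nH]c(CSc3ccc(C(=O)O)cc3)nc12` gives 1900 nM, which sits beyond the scatter from compound 2. For the measured compounds named here, the one single-point step among the measured compounds is a 2.4-fold higher number from compound 1 to compound 3 (0.38 log units; beyond the scatter), a modest shift that is nevertheless beyond the scatter.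

Compound 4 `Cc1cc(I)cc2c(=O)[nH]c(CSc3ncccn3)nc12` is compound 2 with iodo in place of methyl on an aromatic carbon. Going by the values given here, no measured pair isolates exactly this change. Compound 1 carries iodo at the same place as compound 4 does, and its reading in this assay is within the scatter of compound 2; the two differ elsewhere as well, so the comparison is indirect. The step from compound 1 to compound 3 shows that the identity of the halogen at this place can move the number, but it says nothing about methyl against iodo. The expectation for compound 4 is therefore a step of a 1.1-fold higher number from compound 2 to compound 4 (0.04 log units; within the scatter), which is none beyond the scatter. Compound 4 is estimated at 550 nM, with a range from 220 nM to 1400 nM.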

Compound 4, half-maximal inhibitory concentration: 2700 nM
The estimate for compound 4 lay 4.9-fold (0.69 log units) below the measured number, outside the stated range (above it).
By their numbers in this assay, from the lowest: compounds 2 and 1 (each within the scatter of the next); then compounds 3 and 4 (each within the scatter of the next).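

In this assay, replacing methyl with iodo at this place, on an aromatic carbon para to a fused ring, gives a 5.4-fold higher number from compound 2 to compound 4 (0.73 log units; beyond the scatter), so with the rest of compound 2 held constant, the number depends on which of these two groups sits here. For the compounds shown here, the earlier single-place step at this position, a 2.4-fold higher number from compound 1 to compound 3 (0.38 log units; beyond the scatter), compared only two halogens; the new step is the first to set a halogen against methyl, and iodo gives the higher number, meaning weaker inhibition. Nothing in hand bears on the origin of this step, and no cause can be offered.

On these data alone, it remains open whether the higher number is specific to iodo or would follow other replacements of methyl at this place, and an amine or a methoxy group here on the core of compound 2 would help separate those readings. Also open, as far as these compounds go, is whether exchanging methyl and iodo at this place would give a step of similar size and direction with the carboxylic acid-bearing portion of compound 1 in place of the remainder of compound 2.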